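Swapping a Hydroxy for Dimethylamino on a Shared Core

The source may hold more compounds than are shown below. What is called first, only, known or untested is meant among the compounds shown, and "the series" means these compounds.

Two measured compounds share one core and differ only in the group on the pendant aromatic ring. Compound 1 `N#Cc1ccc(C2CC(=O)c3cc(Br)cc(Br)c3N2)cc1` carries a cyano group there, and compound 2 `O=C1CC(c2ccc(O)cc2)Nc2c(Br)cc(Br)cc21` carries a hydroxy group. In a functional assay on MCF7 cells (Homo sapiens) for inhibition, read by sulforhodamine B assay, with a stated time of 48 h (on this read-out lower numbers stand for stronger inhibition of growth and higher numbers for weaker inhibition of growth), compound 1 gives < 100 nM, which is a limit of the assay rather than a number. In this assay compound 2 likewise gives < 100 nM, again a limit and not a number. The step that the two limits leave unreadable from compound 1 to compound 2 therefore cannot be read, as both compounds rest at the limit of < 100 nM in this assay, at which 2 of the 2 values shown sit. Compound 2 thus stands at the edge of what this assay reports, its true position unknown.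

Compound 3 `CN(C)c1ccc(C2CC(=O)c3cc(Br)cc(Br)c3N2)cc1` is so far unmeasured. It differs from compound 2 in one place: dimethylamino in place of hydroxy on an aromatic carbon. Within the data shown here, the only measured step concerns a change at the same position and is unreadable, so it offers no direction. Since both measured values sit at the limit of < 100 nM in this assay, at which 2 of the 2 values shown sit, compound 3 is expected to land near that edge too, and the step that the limit leaves unreadable from compound 2 to compound 3 is expected to stay within the scatter. Compound 3 is estimated at 60 nM, with a range from 10 nM to 300 nM.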

Compound 3, concentration for 50% growth inhibition: > 100000 nM
Compound 3: only a limit was reported; the forecaster's own chance of this, stated with the estimate: 60%; middle value at least 1600-fold (3.22 log units) from the limit.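

This position is clearly not indifferent to what sits on it. In this assay, dimethylamino in place of hydroxy gives an at least 1000-fold higher number from compound 2 to compound 3 (3.00 log units; beyond the scatter), and dimethylamino in place of cyano gives an at least 1000-fold higher number from compound 1 to compound 3 (3.00 log units; beyond the scatter), whereas the step between compound 1 and compound 2 cannot be read and so revealed nothing about the position. Compound 3 rests at the far end of what this assay reports, a limit and not a number, so the true gap may be wider still: the limit of > 100000 nM in this assay, at which 1 of the 3 values shown sits.

The data do not say which part of the change matters: on going from hydroxy to dimethylamino, the hydrogen-bond donor count falls from 1 to 0 while the heavy atoms rise from 1 to 3, so the two shifts cannot be told apart here. As far as these compounds go, a methoxy group or a methylamino group on the same aromatic carbon would help to separate them, and how far compound 1 and compound 2 really lie beyond their shared limit stays unknown.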